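Chloro on the fused ring of compound 3

A few compounds are considered here, and "the series" means these few. Any claim that something is new, unique, unknown or untested is made for them only; others in the source may bear on it.

Of the compounds shown here, three of one shared core have been measured in a functional assay on cells (Cancer cell lines, Homo sapiens) for cytotoxicity, read by sulforhodamine B assay, with a stated time of 48 h; on this read-out lower numbers stand for stronger inhibition of growth and higher numbers for weaker inhibition of growth. Compound 1 `O=C1N=C(N2N=C(c3ccccc3)CC2c2ccccc2O)S/C1=C1/C(=O)Nc2ccccc21` gives 4770 nM, and compound 2 `COc1ccc(C2CC(c3ccccc3)=NN2C2=NC(=O)/C(=C3\C(=O)Nc4ccccc43)S2)cc1` gives 4580 nM; the step of a 1.0-fold lower number from compound 1 to compound 2 (0.02 log units; within the scatter) shows that swapping the aryl group on the saturated carbon changed little. Compound 3 `COc1ccc(C2=NN(C3=NC(=O)/C(=C4\C(=O)Nc5ccccc54)S3)C(c3ccc(OC)cc3)C2)cc1` gives 99600 nM, the highest number of the three, and the step of a 22-fold higher number from compound 2 to compound 3 (1.34 log units; beyond the scatter) is large, so compound 3 stands clearly apart as the weakest of the measured set.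

Compound 4 `COc1ccc(C2=NN(C3=NC(=O)/C(=C4\C(=O)Nc5ccc(Cl)cc54)S3)C(c3ccc(OC)cc3)C2)cc1` keeps the whole of compound 3 and differs by chloro in place of hydrogen on an aromatic carbon. Neither measured step touches this fused ring: one concerns the aryl group on the saturated carbon, the other a methoxy group on a pendant aromatic ring. There is therefore no measured guide to how a chloro group here will act, and the plain expectation is a step of a 1.2-fold lower number from compound 3 to compound 4 (0.10 log units; within the scatter), that is, no change beyond the scatter, with a wide range. Compound 4 is thus expected to give about 80000 nM, somewhere between 20000 nM and 320000 nM.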

Compound 4, concentration for total growth inhibition: 500 nM
The estimate for compound 4 lay 160-fold (2.20 log units) above the measured number; the whole stated range lies above it.
By their numbers in this assay, from the lowest: compound 4; then compounds 2 and 1 (each within the scatter of the next); then compound 3.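

In this assay the system of two fused rings turns out to be a place where a single atom can matter: chloro in place of hydrogen on its six-membered aromatic ring of carbon only gives a 200-fold lower number from compound 3 to compound 4 (2.30 log units; beyond the scatter) and so counts as a large step. Among these compounds, the earlier steps changed only groups elsewhere on the shared core, so this is the first measured sign that this ring affects growth inhibition. Nothing available explains how one chlorine atom produces a change of this size.

Whether the gain is particular to chloro remains open, since the compounds shown carry no fluoro, bromo or methyl group at this place. As far as these compounds go, it is also open whether chloro would act the same way on compound 1 or compound 2, which have different aryl groups.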